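This account rests on a few compounds, and the source may have more. Where it says the series, first, only, none or still open, it means among the compounds named here.

Of the compounds shown here, three built on one shared core have been tested in a functional assay on SW-620 cells (Homo sapiens) for cytotoxicity; on this read-out lower numbers stand for stronger inhibition of growth and higher numbers for weaker inhibition of growth. Compound 1 `COc1ccc(C2=C(c3ccc(SC)cc3)CC3CCCN3C2=O)cc1O` gives 20000 nM, compound 2 `COc1ccc(C2=C(c3ccc(SC)cc3)CC3CCCN3C2=O)cc1OC` gives 3000 nM, and compound 3 `COc1ccc(C2=C(c3ccc(SC)cc3)CC3CCCN3C2=O)cc1` gives 3000 nM. Compound 2 and compound 3 are level at the digits reported, and compound 1 stands apart: the step of a 6.7-fold higher number from compound 2 to compound 1 (0.82 log units; beyond the scatter) arises from hydrogen in place of methyl on an oxygen on an aromatic ring, and the step of a 6.7-fold lower number from compound 1 to compound 3 (0.82 log units; beyond the scatter) follows from hydrogen in place of methoxy on an aromatic carbon once the step of no change at the digits printed from compound 2 to compound 3 (within the scatter) is taken into account.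

Compound 4 `CSc1ccc(C2=C(c3ccc(O)cc3)C(=O)N3CCCC3C2)cc1` has not yet been measured in this assay. It differs from compound 3 by hydrogen in place of methyl on an oxygen on an aromatic ring, which is the same change that separates compound 2 from compound 1, and the two cores differ by hydrogen in place of methoxy on an aromatic carbon. Because the measured step of a 6.7-fold higher number from compound 2 to compound 1 (0.82 log units; beyond the scatter) was of modest size and beyond the scatter, a step of similar size, a 4.0-fold higher number from compound 3 to compound 4 (0.60 log units; beyond the scatter), is expected for compound 4. On that basis compound 4 is estimated at 12000 nM in this assay, with a likely range from 4000 nM to 40000 nM.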

Compound 4, concentration for 50% growth inhibition: > 100000 nM
Compound 4: only a limit was reported; the forecaster's own chance of this, stated with the estimate: 10%; middle value at least 8.3-fold (0.92 log units) from the limit.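

Compound 4 gives > 100000 nM in this assay, which is a limit of the assay and not a number: the limit of > 100000 nM in this assay, at which 1 of the 4 values shown sits. Hydrogen in place of methyl on an oxygen on an aromatic ring gives an at least 33-fold higher number from compound 3 to compound 4 (1.52 log units; beyond the scatter) on this core, so the number moves the same way on both cores, but the size of the step does not carry over from one core to the other: the same change on two cores in this assay, a 6.7-fold higher number (0.82 log units; beyond the scatter) from compound 2 to compound 1 and an at least 33-fold higher number (1.52 log units; beyond the scatter) from compound 3 to compound 4, at least 5.0-fold (0.69 log units) apart, beyond the scatter of two such steps. On these data alone, putting 4-hydroxyphenyl in place of 3-hydroxy-4-methoxyphenyl gives an at least 5.0-fold higher number from compound 1 to compound 4 (0.69 log units; beyond the scatter), yet this step and the one before it both rest on a limit, so their true sizes stay unknown, and two pairs set no rule for other cores.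

The compounds shown leave open how an ethyl group or a longer chain on that oxygen would read. They also leave open what an amine in place of the hydroxy would give on the core of compound 4.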